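The source may hold more compounds than are shown below. What is called first, only, known or untested is meant among the compounds shown, and "the series" means these compounds.

Series notes. The shared core is a saturated ring bearing an acid, attached to an aryl ether; compound 1 is `O=C(O)C1CCN(c2ccc(OCc3ccc(Cl)cc3Cl)cc2)C1`, compound 2 is `O=C(O)C[C@@H]1CCCN1c1ccc(OCc2ccc(Cl)cc2Cl)cc1` and compound 3 is `O=C(O)C[C@H]1CCCN1c1ccc(OCc2ccc(Cl)cc2Cl)cc1`. In a functional assay on cells for agonist activity at Free fatty acid receptor 1 (Mus musculus), read by FLIPR and calcium flux, with a stated time of 100 s (a lower number here means that less compound is needed, a higher number that more compound is needed for the effect), compound 2 gives 4500 nM. For compound 1 this assay reports only a limit, > 16000 nM. For compound 3 this assay also reports only a limit, > 17000 nM. Compound 2 thus holds the only number shown in this assay and serves as the point of comparison for the series. Going by the values given here, the one measured step, an at least 3.7-fold higher number from compound 2 to compound 3 (0.57 log units; beyond the scatter), rests on the fact that compounds 2 and 3 differ only in the configuration as drawn together with the limit of > 17000 nM in this assay, at which 1 of the 3 values shown sits.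

Compound 4 is `Cc1cc(OCc2ccc(Cl)cc2Cl)ccc1N1CCC[C@H]1CC(=O)O`. It differs from compound 2 by methyl in place of hydrogen on an aromatic carbon. Among the compounds with values here, no measured step covers methyl in place of hydrogen on an aromatic carbon; the single measured step, an at least 3.7-fold higher number from compound 2 to compound 3 (0.57 log units; beyond the scatter), concerns configuration alone and gives no guide to the size or direction of this change. The step for compound 4 is therefore expected to stay within the scatter, as a 1.1-fold lower number from compound 2 to compound 4 (0.05 log units; within the scatter). The estimate for compound 4 in this assay is 4000 nM, with a range from 1000 nM to 15000 nM.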

Compound 4, half-maximal effective concentration: 14000 nM
Estimate against measurement, compound 4: 3.5-fold (0.54 log units) below; measured number inside the range.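

Methyl in place of hydrogen on an aromatic carbon gives in this assay a 3.1-fold higher number from compound 2 to compound 4 (0.49 log units; beyond the scatter) and so shows that this position, ortho to a group of 9 heavy atoms and meta to a large group, does not tolerate even this single added carbon without a change in the number. Going by these compounds alone, the one earlier measured step concerned configuration at a saturated ring carbon alone, so this is the first sign that a change on the aromatic ring also moves the number, here towards more compound being needed for the effect. Nothing in the data at hand offers a reason for this step.

Going by these compounds, whether the higher number belongs to methyl itself or would also follow from a fluorine atom, a methoxy group or a chlorine atom on the same aromatic carbon stays open, as a single step gives no trend for this position. Also open, on these data alone, is how the same methyl would act in the configuration of compound 3, where > 17000 nM is a limit of the assay and offers no number to start from.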